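Dropping a Methyl from Compound 3

The source may report more compounds than this note shows. Statements on the series, on what has been measured and on what is new or still open speak of the compounds shown alone.

Of the compounds shown here, three have been measured in a functional assay on HCT-116 cells (Homo sapiens); a lower number here means a stronger inhibitor of growth, a higher number a weaker inhibitor of growth. Compound 1 (`Oc1cc(-c2ccc(Cl)cc2)nc2ncccc12`) gives 32400 nM, compound 2 (`COc1ccc(-c2cc(O)c3c(C)cc(C)nc3n2)cc1`) gives 36300 nM, and compound 3 (`COc1ccccc1-c1cc(O)c2ccc(C)nc2n1`) gives 38000 nM. All three numbers lie within the scatter of one another, so compound 3 stands level with both of the others.

The next compound is compound 4 (`COc1ccccc1-c1cc(O)c2cccnc2n1`), which differs from compound 3 in a single place: hydrogen in place of methyl on an aromatic carbon. Hydrogen takes the place of methyl on an aromatic carbon, next to the ring nitrogen.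

Among the measured compounds shown here, no pair of measured compounds differs in one place only, so the size of this step has not been seen directly. For the measured compounds named here, the only guide is indirect. Compound 1 has no methyl on the shared core and gives 32400 nM, while compound 2 carries methyl there and gives 36300 nM. These two compounds also differ in other places, so the comparison is loose, but it offers no sign of a large effect. A step beyond the scatter in this assay is therefore not expected in either direction. The estimated step of a 1.1-fold lower number from compound 3 to compound 4 (0.04 log units; within the scatter) stays within the scatter. For compound 4 the expected value is 35000 nM, with an estimated range from 18000 nM to 70000 nM.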

Compound 4, concentration for 50% growth inhibition: 27500 nM
Compound 4: middle estimate off by 1.3-fold (0.10 log units), on the high side; the range from low to high includes it.
By their numbers in this assay, from the lowest: compounds 4, 1, 2 and 3 (each within the scatter of the next).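

In this assay, the step of a 1.4-fold lower number from compound 3 to compound 4 (0.14 log units; within the scatter) lies within the scatter, so methyl and hydrogen on this aromatic carbon, next to the ring nitrogen, cannot be told apart by this read-out. Among the compounds shown here, the earlier compounds could offer only a loose hint about this position, as they differed in other places as well, whereas this pair isolates the single change and shows directly that removing the methyl leaves no effect that can be distinguished from the scatter. No accompanying measurement offers an explanation for this result.

What the compounds shown leave open is whether this carbon is insensitive to substitution in general or only to the exchange of methyl and hydrogen, since a larger or differently functional group, such as an amine, a carboxylic acid or a longer chain, could still produce a step beyond the scatter. Going by these compounds, it also remains open whether the same exchange would stay within the scatter when the rest of the molecule differs, as it does in compound 1 and compound 2, which have no one-place partner here.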